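Triazole substituent shift in a dihydrothiopyran dioxide oxazolidinone series

The source may report more compounds than this note shows. Statements on the series, on what has been measured and on what is new or still open speak of the compounds shown alone.

Measured compounds:
compound 1 `Cc1cn(C[C@H]2CN(c3ccc(C4=CCS(=O)(=O)CC4)c(F)c3)C(=O)O2)nn1` – 25000 nM
compound 2 `CCc1cn(C[C@H]2CN(c3ccc(C4=CCS(=O)(=O)CC4)c(F)c3)C(=O)O2)nn1` – > 200000 nM

Compound 1 `Cc1cn(C[C@H]2CN(c3ccc(C4=CCS(=O)(=O)CC4)c(F)c3)C(=O)O2)nn1` gives 25000 nM in an assay for binding affinity to Amine oxidase [flavin-containing] A (Homo sapiens); a higher number here means a weaker inhibitor, a lower number a stronger inhibitor. Compound 2 `CCc1cn(C[C@H]2CN(c3ccc(C4=CCS(=O)(=O)CC4)c(F)c3)C(=O)O2)nn1` returns only a limit in this assay, > 200000 nM, so its standing on the numbers shown is an open range rather than a value. Within the data shown here, the single measured step is an at least 8.0-fold higher number from compound 1 to compound 2 (0.90 log units; beyond the scatter); its size is known only as a lower bound due to the limit of > 200000 nM in this assay, at which 1 of the 2 values shown sits.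

Compound 3 `Cc1cnnn1C[C@H]1CN(c2ccc(C3=CCS(=O)(=O)CC3)c(F)c2)C(=O)O1` is not yet measured. It differs from compound 2 by 5-methyl-1H-1,2,3-triazol-1-yl in place of 4-ethyl-1H-1,2,3-triazol-1-yl on a saturated chain carbon bound to a saturated ring carbon. Among the measured compounds shown here, this change removes the longer chain whose introduction produced the weakening seen from compound 1 to compound 2, but it also places the methyl on a different ring carbon of the triazole, for which no measured pair exists. The measured step therefore bears on only part of the change. A return toward the level of compound 1 is expected, though the relocation of the methyl leaves wide uncertainty, and the estimated step is an at least 4.0-fold lower number from compound 2 to compound 3 (0.60 log units; beyond the scatter). For compound 3 the expected value in this assay is 50000 nM, with a range from 15000 nM to 200000 nM.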

Compound 3, inhibition constant: 4500 nM
Compound 3: the middle estimate sits 11-fold (1.05 log units) above what was measured; measured number outside the range, below it.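

In this assay, moving the methyl alone, with 5-methyl-1H-1,2,3-triazol-1-yl in place of 4-methyl-1H-1,2,3-triazol-1-yl, gives a 5.6-fold lower number from compound 1 to compound 3 (0.74 log units; beyond the scatter), so the ring carbon that carries the substituent affects the value independently of chain length, and compound 3 has the lowest number of the three compounds. Against 4-ethyl-1H-1,2,3-triazol-1-yl, the same group gives an at least 44-fold lower number from compound 2 to compound 3 (1.64 log units; beyond the scatter), a large change that combines a shorter chain with a relocated substituent and cannot be divided between the two. The size of this step is only a lower bound, and the value of compound 2 is a limit rather than a number: the limit of > 200000 nM in this assay, at which 1 of the 3 values shown sits.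

The compounds shown do not establish whether the gain at the ring carbon of 5-methyl-1H-1,2,3-triazol-1-yl would persist with a longer chain such as ethyl or propyl there, or how a hydroxymethyl or an amine at that carbon would compare. Comparison with the unsubstituted 1H-1,2,3-triazol-1-yl group also remains open, so the data do not show whether either methyl placement raises or lowers the number relative to having no substituent.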